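This account rests on a few compounds, and the source may have more. Where it says the series, first, only, none or still open, it means among the compounds named here.

Measured so far:
Compound 1, `Cn1c(-c2cccnc2)nc2ccc(F)cc21`: 677 nM
Compound 2, `Fc1cncc(-c2nc3cc(F)c(Cl)cc3n2C2CC2)c1`: 251 nM
Compound 3, `CS(=O)(=O)c1ccc2c(c1)nc(-c1cccnc1)n2C1CC1`: > 10000 nM

Of the compounds shown here, three sharing one core have been tested in an assay on V79 cells for inhibition of cytochrome P450 11B1, mitochondrial (Homo sapiens), read by HTRF, with a stated time of 1 h; a lower number here means a stronger inhibitor, a higher number a weaker inhibitor. Compound 1 gives 677 nM in this assay. Compound 2 gives 251 nM, the lowest of the two numbers; compound 1 sits at a higher number, a gap that lies beyond the usual scatter of repeated measurements. For compound 3 this assay reports only a limit, > 10000 nM, and not a number, as noted in the limit of > 10000 nM in this assay, at which 1 of the 3 values shown sits.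

The next compound, compound 4, `N#Cc1cc2c(cc1F)nc(-c1cncc(F)c1)n2C1CC1`, differs from compound 2 in one place: cyano in place of chloro on an aromatic carbon. Among the measured compounds shown here, no measured pair shows exactly this exchange, so the size of the step has to be guessed from the three values alone. A moderate loss of potency is expected, of a size that may or may not exceed the scatter, so the estimated step from compound 2 to compound 4 is a 2.0-fold higher number from compound 2 to compound 4 (0.30 log units; within the scatter). Compound 4 is therefore expected to give about 500 nM in this assay. For compound 4 the range of the estimate runs from 150 nM to 2000 nM.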

Compound 4, half-maximal inhibitory concentration: 225 nM
Compound 4: middle estimate off by 2.2-fold (0.35 log units), on the high side, within the range that was stated.
By their numbers in this assay, from the lowest: compounds 4 and 2 (each within the scatter of the next); then compound 1. At a limit, above all of these: compound 3.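

In this assay, the step for cyano in place of chloro on this aromatic carbon, ortho to a fluoro group, is a 1.1-fold lower number from compound 2 to compound 4 (0.05 log units; within the scatter). This position therefore accepts a chloro group of one heavy atom or a cyano group of two, with its triple bond and hydrogen-bond acceptor, and the two compounds cannot be told apart by this read-out. Until this pair, no two compounds shown differed in only one place, so no single exchange could be read directly; still, nothing in the data shown bears on why these two groups read alike here.

On these data alone, it remains open how much further this position can be changed: an amine, a carboxylic acid or a longer chain on the same aromatic carbon would show whether the match between chloro and cyano extends to quite different groups. As far as these compounds go, it is also open whether cyano and chloro would still read alike in a compound without the neighbouring fluoro group, since both compounds in this pair carry it.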